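The compounds below may be only part of what the source reports. "The series", "measured", "known", "first", "only" and "open" are said of these compounds alone.

Among the compounds with values here, in an ADME assay on microsomes from liver (Rattus norvegicus) for metabolic stability, read by LC-MS, using NADPH, at 37 degrees C (on this read-out higher numbers stand for a longer-lived compound and lower numbers for a shorter-lived compound), compound 2 `Cc1oc(-c2c(Cl)cccc2Cl)nc1CN1CCC(C(=O)NCCCN2C[C@H](C)C[C@H](C)C2)CC1` gives 0.0483 h, and this is the only plain number among the three measured compounds. Compound 1 `Cc1ccccc1-c1nc(CN2CCC(C(=O)NCCCN3CCC(C)(C)CC3)CC2)c(C)o1` reaches a limit of this assay at > 0.5 h. Compound 3 `CCCN(CCC)CCNC(=O)C1CCN(Cc2nc(-c3ccccc3C)oc2C)CC1` likewise reaches a limit of this assay at > 0.5 h. Between these two, the change of dipropylamino in place of (4,4-dimethylpiperidin-1-yl)methyl on a saturated chain carbon, two bonds along the chain from an amide-type nitrogen gives a step that the two limits leave unreadable from compound 1 to compound 3, so its size cannot be read.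

Compound 4 `Cc1ccc(-c2nc(CN3CCC(C(=O)NCCCN4C[C@H](C)C[C@H](C)C4)CC3)c(C)o2)cc1` differs from compound 2 by 4-methylphenyl in place of 2,6-dichlorophenyl on an aromatic carbon. No measured step touches this aromatic position, so nothing shown gives a size for it. What the shown values offer is only (the limit of > 0.5 h in this assay, at which 2 of the 3 values shown sit), reached by compounds 1 and 3, whose structures do not carry the 2,6-dichlorophenyl group. On that footing the expected step is a 7.2-fold higher number from compound 2 to compound 4 (0.86 log units; beyond the scatter), toward a longer-lived compound. Compound 4 is therefore estimated to give 0.35 h in this assay, within a range from 0.08 h to 1.5 h.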

Compound 4, half-life: > 0.5 h
Compound 4 was reported as a limit; the forecaster's own chance of this, stated with the estimate: 40%; middle value at least 1.4-fold (0.15 log units) away from the limit.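

Within the data shown here, replacing 2,6-dichlorophenyl with 4-methylphenyl on this aromatic carbon of the five-membered ring gives the first readable step at this position, with the rest of the structure unchanged: an at least 10-fold higher number from compound 2 to compound 4 (1.01 log units; beyond the scatter). Compound 4 gives > 0.5 h in this assay, which is a limit and not a number. Only compound 2 now has a plain number, and this position is the one place where it differs from compound 4: the limit of > 0.5 h in this assay, at which 3 of the 4 values shown sit.

The change removes two chlorine atoms and adds one methyl group at a different place on the phenyl ring, so this pair cannot separate those parts; plain phenyl, 4-chlorophenyl or 2,6-dimethylphenyl at this position would help to do so. Steps between compounds that both sit at the limit cannot be read, so those compounds cannot be ranked.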